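This account rests on a few compounds, and the source may have more. Where it says the series, first, only, none or still open, it means among the compounds named here.

Measured so far in an ADME assay on S2 cells (Drosophila melanogaster) for cytotoxicity, read by MTT assay; a higher number here means that more compound is needed for the effect, a lower number that less compound is needed:
Compound 1 `COC(=O)/C=C/[C@H]1C[C@@H](O)[C@@H](O)C1` gives > 350000 nM, which is a limit of the assay and not a number.
Compound 2 `CN(C)C(=O)/C=C/[C@H]1C[C@@H](O)[C@@H](O)C1` gives > 250000 nM, again only a limit.
Compound 3 `NC(=O)/C=C/[C@H]1C[C@@H](O)[C@@H](O)C1` gives > 250000 nM, also a limit.

Compound 3 thus stands at the limit of > 250000 nM in this assay, at which 2 of the 3 values shown sit, while compound 1 sits at the limit of > 350000 nM in this assay, at which 1 of the 3 values shown sits. With no numbers among the three, the steps a step that the two limits leave unreadable from compound 1 to compound 2, a step that the two limits leave unreadable from compound 1 to compound 3 and a step that the two limits leave unreadable from compound 2 to compound 3 cannot be sized. The next compound, compound 4 `CNC(=O)/C=C/[C@H]1C[C@@H](O)[C@@H](O)C1`, differs from compound 3 by methyl in place of hydrogen on an amide-type nitrogen. With compound 3 resting at the limit of > 250000 nM in this assay, at which 2 of the 3 values shown sit, no step beyond the scatter is expected for compound 4 in this assay; the expected step is a step that the limit leaves unreadable from compound 3 to compound 4. Compound 4 is estimated at 300000 nM, within 100000 nM to 1000000 nM, and most likely to be reported once more as a limit.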

Compound 4, half-maximal effective concentration: > 250000 nM
Compound 4: only a limit was reported; the forecaster's own chance of this, stated with the estimate: 90%; the middle value lies beyond the limit too.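

Among these compounds, compound 4 is reported only as a limit, as are compound 1, compound 2 and compound 3, so no step to compound 4 can be read. The compounds shown leave open where any half-maximal effective concentration actually lies.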